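Swapping methylsulfonyl for dimethylamino on the benzyl ring

The source may hold more compounds than are shown below. What is called first, only, known or untested is meant among the compounds shown, and "the series" means these compounds.

In a physicochemical assay for solubility, using the shake flask method, in simulated intestinal fluid, measured as kinetic solubility, with a stated time of 2 h, at 25 degrees C, at pH 6.5 (on this read-out lower numbers stand for lower solubility and higher numbers for higher solubility), the measured compounds read as follows.
- compound 1 `Cc1noc(-c2nc(C)c3c(c2N)C(=O)N(CC2CCNCC2)C3=O)n1` gives 160000 nM
- compound 2 `Cc1noc(-c2nc(C)c3c(c2N)C(=O)N(Cc2ccncc2)C3=O)n1` gives 26400 nM
- compound 3 `Cc1noc(-c2nc(C)c3c(c2N)C(=O)N(Cc2ccc(S(C)(=O)=O)cc2)C3=O)n1` gives < 5000 nM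

The reading for compound 3 of < 5000 nM is a limit of the assay and not a number. It is the limit of < 5000 nM in this assay, at which 1 of the 3 values shown sits.

Compound 4 `Cc1noc(-c2nc(C)c3c(c2N)C(=O)N(Cc2ccc(N(C)C)cc2)C3=O)n1` carries dimethylamino in place of methylsulfonyl on an aromatic carbon. The rest of compound 3 stays as it is.

Among the measured compounds shown here, no measured step makes this exact swap, so the evidence is indirect. The nearest steps replace the whole group on the chain carbon. There is a 6.1-fold lower number from compound 1 to compound 2 (0.78 log units; beyond the scatter), then an at least 32-fold lower number from compound 1 to compound 3 (1.50 log units; beyond the scatter), and finally an at least 5.2-fold lower number from compound 2 to compound 3 (0.72 log units; beyond the scatter). All three lie beyond the scatter, and the largest is the one that leads to the 4-(methylsulfonyl)phenyl of compound 3. Compound 4 keeps that six-membered aromatic ring of carbon only and changes just one group on it. A drop or rise of that size is therefore not expected, and the expected result is a reading close to that of compound 3, with no clear direction beyond the scatter.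

The expected change is a number no lower from compound 3 to compound 4 (the limit leaves the size open). For compound 4 the estimated value is 5000 nM, within an expected range of 2500 nM to 15000 nM.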

Compound 4, solubility: 7400 nM
For compound 4 the middle estimate is 1.5-fold (0.17 log units) below the measured one; the range from low to high includes it.
By their numbers in this assay, from the lowest: compound 4; then compound 2; then compound 1. At a limit, below all of these: compound 3.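

Compound 3 reached only a limit, not a number, in this assay, so the methylsulfonyl compound could mark no exact level for a substituted benzyl ring: the limit of < 5000 nM in this assay, at which 1 of the 4 values shown sits.

On these data alone, compound 4 supplies that missing number, and changing this one group on the aromatic carbon gives an at least 1.4-fold higher number from compound 3 to compound 4 (0.17 log units; that floor lies within the scatter); the true size of the swap therefore remains unknown, and a floor of this size cannot show a real gain. The measured value also turns the comparison with the other two chain groups from a floor into a firm step, with a 3.6-fold lower number from compound 2 to compound 4 (0.55 log units; beyond the scatter) and a 22-fold lower number from compound 1 to compound 4 (1.33 log units; beyond the scatter), so replacing the whole group on the chain carbon still shows a clear difference, while this single change on the ring shows none beyond the scatter.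

The compounds shown leave open how far the reading of compound 3 lies under its limit, and with it how large the swap from methylsulfonyl to dimethylamino really is. They also leave open how another group at the same place on the ring, such as a carboxylic acid or a morpholin-4-yl group, would read in this assay.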